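Removing a methoxy group: cell effects of compound 4 expected

This account rests on a few compounds, and the source may have more. Where it says the series, first, only, none or still open, it means among the compounds named here.

Measured compounds:
compound 1 `COC(=O)[C@H](CO)NC(=O)/C=C/c1ccc(C)cc1` gives 100%
compound 2 `COC(=O)[C@H](COC(=O)/C=C/c1ccc(F)cc1)NC(=O)/C=C/c1ccc(F)cc1` gives 21.1%
compound 3 `COC(=O)[C@@H]1COC(/C=C/c2ccc(OC)cc2)=N1` gives 94.8%

Three compounds were tested in an ADME assay on Vero cells (Chlorocebus sabaeus) for cytotoxicity, read by WST assay, tested at 50 ug/mL; a lower number here means a stronger effect, a higher number a weaker effect of the compound at the concentration tested. Compound 1 and compound 3 both leave the cells largely untouched; the gap between them lies within the usual scatter, so neither can be called weaker or stronger than the other. Compound 2 stands far apart, with a gap to compound 3 that lies well beyond the scatter, showing a much stronger effect on the cells.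

Compound 4 `COC(=O)[C@@H]1COC(/C=C/c2ccccc2)=N1` is the unmeasured compound. It differs from compound 3 in one place: hydrogen in place of methoxy on an aromatic carbon. Within the data shown here, no step between measured compounds describes this exact change, so the expectation rests on compound 3 alone. Because compound 3 gives 94.8% in this assay, compound 4 is expected to behave much the same. The step this expectation means is a number 1.8 percentage points lower from compound 3 to compound 4 (within the scatter), estimated to stay within the scatter. Compound 4 is therefore estimated at 93%, most likely between 78% and 100%.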

Compound 4, a percentage reported as activity, at one concentration (the size of the read-out at that concentration, not a potency): 68.6%
Compound 4: the middle estimate sits 24.4 percentage points above what was measured, outside the stated range (below it).
By their numbers in this assay, from the lowest: compound 2; then compound 4; then compounds 3 and 1 (each within the scatter of the next).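

In this assay, the methoxy group on the aromatic ring, para to a large group, proves to matter: hydrogen in its place gives a number 26.2 percentage points lower from compound 3 to compound 4 (beyond the scatter). Among these compounds, no earlier pair differed in only one place, so this is the first view of a single change, and it shows that this position alone can move the reading towards a stronger effect on the cells. Nothing available explains why this change has such an effect.

With only methoxy and hydrogen compared at this position, the compounds shown leave open how an amine, a carboxylic acid or a longer chain such as ethoxy would read there. They also leave open whether the same swap would give a similar step on a different core.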